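The source may report more compounds than this note shows. Statements on the series, on what has been measured and on what is new or still open speak of the compounds shown alone.

Of the compounds shown here, three share one core and have been tested in an ADME assay on the whole organism with Oryza sativa as the target, tested at 1 uM; on this read-out higher numbers stand for a weaker effect at the one concentration tested and lower numbers for a stronger effect. Compound 1, `C[C@H](NC(=O)Nc1ccccc1F)c1ccccc1`, gives 92%. Compound 2, `C[C@H](NC(=O)Nc1ccccc1Cl)c1ccccc1`, gives 104%, and compound 3, `C[C@H](NC(=O)Nc1cc(F)ccc1F)c1ccccc1`, gives 98%. Compound 1 thus stands at the lower end of the three numbers: the step of a number 6 percentage points higher from compound 1 to compound 3 (within the scatter) is within the scatter, while the step of a number 12 percentage points higher from compound 1 to compound 2 (beyond the scatter) is beyond it.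

Compound 4, `C[C@H](NC(=O)Nc1c(F)cccc1F)c1ccccc1`, is not yet measured. It differs from compound 1 by fluoro in place of hydrogen on an aromatic carbon. Going by the values given here, the one measured step that bears on this change is the one to compound 3, where fluoro in place of hydrogen on an aromatic carbon gave a number 6 percentage points higher from compound 1 to compound 3 (within the scatter), a change within the scatter. The step to compound 2 involves a different change and speaks less directly to compound 4.

On that basis, the expected step for compound 4 is a number 4 percentage points higher from compound 1 to compound 4 (within the scatter), in other words no movement beyond the scatter. Compound 4 is therefore estimated at 96%, with a range from 86% to 106%.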

Compound 4, a percentage reported as activity, at one concentration (the size of the read-out at that concentration, not a potency): 99%
Compound 4: the middle estimate sits 3 percentage points below what was measured; the measured number falls inside the stated range.
By their numbers in this assay, from the lowest: compounds 1, 3, 4 and 2 (each within the scatter of the next, the first and the last beyond it).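

In this assay, fluoro in place of hydrogen on the aromatic carbon ortho to a large group gives a number 7 percentage points higher from compound 1 to compound 4 (within the scatter) and so adds a second site where this change stays inside the noise of the assay. Alongside a number 6 percentage points higher from compound 1 to compound 3 (within the scatter) that makes two sites on this ring where the same swap produces no step beyond the scatter, while the one such step among these compounds remains a number 12 percentage points higher from compound 1 to compound 2 (beyond the scatter) for chloro in place of fluoro. Nothing on hand explains why the added fluoro group shifts the number so little.

Still open, from the compounds shown here alone, is whether a larger group at this site, such as chloro, methyl or methoxy, would move the number beyond the scatter. Going by these compounds, an amine or a carboxylic acid there is equally open.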